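The compounds below may be only part of what the source reports. "The series", "measured", "known", "first", "only" and "open" are said of these compounds alone.

Measured in a functional assay (microsomes, liver) with Rattus norvegicus as the target; a higher number here means a weaker inhibitor, a lower number a stronger inhibitor:
- Compound 1 `Cc1c(C)c2c(c(C)c1N)CC(C)(C)O2`: 760 nM
- Compound 2 `Cc1c(C)c2c(c(C)c1N)CC(C)(CSc1ccccc1)O2`: 270 nM
- Compound 3 `COCC1(C)Cc2c(C)c(N)c(C)c(C)c2O1`: 300 nM

At 300 nM, compound 3 lies within the scatter of its nearest neighbour, as a 1.1-fold higher number from compound 2 to compound 3 (0.05 log units; within the scatter) shows, while its furthest neighbour is separated by a 2.5-fold lower number from compound 1 to compound 3 (0.40 log units; beyond the scatter). Compound 4 `Cc1c(C)c2c(c(C)c1N)CC(C)(CBr)O2` carries bromo in place of methoxy on a saturated chain carbon bound to a saturated ring carbon. Among the compounds with values here, no measured step makes this exchange directly. The nearest evidence comes from the same place: the modest steps of a 2.8-fold lower number from compound 1 to compound 2 (0.45 log units; beyond the scatter) and a 2.5-fold lower number from compound 1 to compound 3 (0.40 log units; beyond the scatter), together with the exchange of phenylsulfanyl for methoxy, a 1.1-fold higher number from compound 2 to compound 3 (0.05 log units; within the scatter). No step beyond the scatter is therefore expected in this assay: the estimate is a 1.0-fold lower number from compound 3 to compound 4 (0.01 log units; within the scatter). For compound 4 the expected value is 290 nM, with an estimated range of 120 nM to 700 nM.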

Compound 4, half-maximal inhibitory concentration: 300 nM
For compound 4 the middle estimate is 1.0-fold (0.01 log units) below the measured one, and the stated range covers the measured number.
By their numbers in this assay, from the lowest: compounds 2, 3 and 4 (each within the scatter of the next); then compound 1.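

In this assay bromo, with no hydrogen-bond acceptor, stands level with methoxy, which has one (no change at the digits printed from compound 3 to compound 4 (within the scatter)), and with phenylsulfanyl (a 1.1-fold higher number from compound 2 to compound 4 (0.05 log units; within the scatter)). A third group on the saturated chain carbon thus gives a step from hydrogen (a 2.5-fold lower number from compound 1 to compound 4 (0.40 log units; beyond the scatter)) that lies beyond the scatter, and the three substituted compounds remain within the scatter of one another. Nothing shown gives a reason for this. From the compounds shown here alone, whether an amine, a carboxylic acid or a longer chain at this place would join these three remains open.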